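The source may report more compounds than this note shows. Statements on the series, on what has been measured and on what is new or still open speak of the compounds shown alone.

In a functional assay on RS4-11 cells (Homo sapiens) for inhibition, read by CCK-8 assay, with a stated time of 48 h (a lower number here means a stronger inhibitor, a higher number a weaker inhibitor), compound 1 `COc1ccc(Oc2ccccc2-c2ccsc2S(=O)(=O)N2CCN(C(=S)Nc3ccc([N+](=O)[O-])cc3)CC2)cc1OC` gives > 50000 nM, which is a limit. Compound 2 `COc1ccc(Oc2ccc([N+](=O)[O-])cc2-c2ccsc2S(=O)(=O)N2CCN(C(=S)Nc3ccc([N+](=O)[O-])cc3)CC2)cc1OC` gives > 50000 nM, also a limit. Compound 3 `COc1ccc(Oc2ccccc2-c2ccsc2S(=O)(=O)N2CCN(C(=O)Nc3ccc([N+](=O)[O-])cc3)CC2)cc1OC` gives > 50000 nM, again a limit. Within the data shown here, compound 1 therefore has no readable number, and the series so far stands at the limit of > 50000 nM in this assay, at which 3 of the 3 values shown sit. Compound 4 `O=[N+]([O-])c1ccc(NC(=S)N2CCN(S(=O)(=O)c3sccc3-c3ccccc3Oc3ccc(O)c(O)c3)CC2)cc1` carries one change: 3,4-dihydroxyphenyl in place of 3,4-dimethoxyphenyl on an oxygen on an aromatic ring. Neither a step that the two limits leave unreadable from compound 1 to compound 2 nor a step that the two limits leave unreadable from compound 1 to compound 3 gives a size to carry over, and neither touches this group. Any direction is therefore a loose expectation, taken towards stronger inhibition in this assay. The expected change is an at least 2.5-fold lower number from compound 1 to compound 4 (0.39 log units; beyond the scatter). For compound 4 the estimate is 20000 nM, with an expected range from 4000 nM to 50000 nM.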

Compound 4, half-maximal inhibitory concentration: 9000 nM
For compound 4 the middle estimate is 2.2-fold (0.35 log units) above the measured one; the range from low to high includes it.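

Among these compounds, the aryl group on the oxygen on an aromatic ring is the first change to give a readable value: 3,4-dihydroxyphenyl in place of 3,4-dimethoxyphenyl gives an at least 5.5-fold lower number from compound 1 to compound 4 (0.74 log units; beyond the scatter). The other steps cannot be read, so this position alone has moved off the ceiling: the limit of > 50000 nM in this assay, at which 3 of the 4 values shown sit.

From the compounds shown here alone, whether both hydroxyl groups are needed remains open, as does whether an amine or a carboxylic acid on this ring would serve equally. Going by these compounds, it is also open whether 3,4-dihydroxyphenyl would act the same way on the cores of compound 2 and compound 3.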